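This account rests on a few compounds, and the source may have more. Where it says the series, first, only, none or still open, it means among the compounds named here.

In a functional assay on A549 cells (Homo sapiens) for antiproliferative activity, read by MTT assay, with a stated time of 72 h (a lower number here means a stronger inhibitor, a higher number a weaker inhibitor), compound 1 `C#Cc1cccc(Nc2ncnc3cc(OC)c(OCCCN4CCNCCNCC4)cc23)c1` gives > 50000 nM as a limit of the assay and not a number. Going by the values given here, compound 2 `COc1cc2ncnc(Nc3cccc(I)c3)c2cc1OCCCN1CCNCCNCC1` gives 26200 nM as the only true number so far. Compound 3 `CCc1cc(Br)ccc1Nc1ncnc2cc(OC)c(OCCCN3CCNCCNCC3)cc12` has 4-bromo-2-ethylphenyl in place of the 3-iodophenyl of compound 2 on a nitrogen on an aromatic ring (4-bromo-2-ethylphenyl in place of 3-iodophenyl on a nitrogen on an aromatic ring). Among the compounds with values here, the only measured step (an at least 1.9-fold lower number from compound 1 to compound 2 (0.28 log units; that floor lies within the scatter)) is iodo in place of ethynyl on an aromatic carbon, a different change, so it offers weak guidance. The change expected in this assay is therefore none beyond the scatter, with the estimated step (a 1.1-fold higher number from compound 2 to compound 3 (0.06 log units; within the scatter)) small and without a firm direction. For compound 3 the estimated value is 30000 nM with an expected range from 12000 nM to 60000 nM in this measurement.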

Compound 3, half-maximal inhibitory concentration: > 50000 nM
Compound 3 ended at the assay's limit (the forecaster's own chance of this, stated with the estimate: 35%); middle value at least 1.6-fold (0.22 log units) away from the limit.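

In this assay the change to 4-bromo-2-ethylphenyl on this nitrogen gives an at least 1.9-fold higher number from compound 2 to compound 3 (0.28 log units; that floor lies within the scatter), so this larger group brings no gain over 3-iodophenyl, although that floor alone does not prove a loss. The step from compound 1 to compound 3 cannot be read, and the true size of the step above stays hidden because of where the values end: the limit of > 50000 nM in this assay, at which 2 of the 3 values shown sit.

Which part of 4-bromo-2-ethylphenyl matters remains open. So does whether an amine on this phenyl ring, or a longer chain in place of its ethyl, would lower the number.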